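Adding a Second Chloro to Sulfonamides That Show No Inhibition

The compounds below may be only part of what the source reports. "The series", "measured", "known", "first", "only" and "open" are said of these compounds alone.

Compound 1 `O=S(=O)(Nc1ccc2oc(-c3ccccc3)nc2c1)c1cccc(C(F)(F)F)c1`: > 63000 nM
Compound 2 `O=S(=O)(Nc1ccc2oc(-c3ccccc3)nc2c1)c1cccc(Cl)c1`: > 63000 nM
Compound 3 `O=[N+]([O-])c1cc(S(=O)(=O)Nc2ccc(-c3nc4ccccc4o3)cc2)ccc1Cl`: > 63000 nM

Each of these three values is a limit of the assay, not a measured number. In an assay on isolated protein for inhibition of malate dehydrogenase, mitochondrial (Sus scrofa), with stated times of 45 min and 30 min (on this read-out lower numbers stand for stronger inhibition and higher numbers for weaker inhibition), compound 1 gives > 63000 nM as a limit. Compound 2 likewise gives > 63000 nM as a limit in this assay. Compound 3 also reaches only the limit of > 63000 nM in this assay. Within the data shown here, the one step between measured compounds, a step that the two limits leave unreadable from compound 1 to compound 2, therefore tells nothing about the size or direction of a change because of the limit of > 63000 nM in this assay, at which 3 of the 3 values shown sit.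

Compound 2 stands at that limit with no number of its own. Compound 4 `O=S(=O)(Nc1ccc2oc(-c3ccccc3)nc2c1)c1ccc(Cl)c(Cl)c1` differs from it by chloro in place of hydrogen on an aromatic carbon. Among the measured compounds shown here, no measured step bears on this change, and all that the three compounds show is that the shared core has not produced a readable inhibition at any substitution tried. Compound 4 is therefore expected to remain at the limit, estimated at 63000 nM within a range from 20000 nM to 200000 nM. The expected step of a number no higher from compound 2 to compound 4 (the limit leaves the size open) is thus none beyond the scatter.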

Compound 4, half-maximal inhibitory concentration: > 63000 nM
Compound 4 was reported as a limit; the forecaster's own chance of this, stated with the estimate: 85%; the middle value sits exactly at the limit.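

No step can be read from compound 2 to compound 4, because both values are limits and not numbers: the limit of > 63000 nM in this assay, at which 4 of the 4 values shown sit.

The compounds shown leave open whether any substitution on the shared core gives readable inhibition, and what the added chloro does to it.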